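The source may hold more compounds than are shown below. What is called first, only, known or untested is meant among the compounds shown, and "the series" means these compounds.

In a functional assay on NCI-H460 cells (Homo sapiens) for positive allosteric modulation, read by MTT assay, with stated times of 2 h and 72 h, tested at 1 uM (on this read-out lower numbers stand for stronger inhibition and higher numbers for weaker inhibition), compound 1 `CCCc1ccc(C(=O)Nc2ccccc2-c2nnn(-c3cccc(OC)c3)n2)cc1` gives 207 nM, compound 2 `COc1cccc(-n2nnc(-c3ccccc3NC(=O)c3ccc(N)cc3)n2)c1` gives 217 nM, and compound 3 `COc1cccc(-n2nnc(-c3ccccc3NC(=O)c3ccc(NC(C)=O)cc3)n2)c1` gives 725 nM, the highest of the three numbers. The steps leading to compound 3 were modest but beyond the scatter: a 3.5-fold higher number from compound 1 to compound 3 (0.54 log units; beyond the scatter) and a 3.3-fold higher number from compound 2 to compound 3 (0.52 log units; beyond the scatter), whereas a 1.0-fold higher number from compound 1 to compound 2 (0.02 log units; within the scatter). Compound 4 `COc1cccc(-n2nnc(-c3ccccc3NC(=O)c3ccc(N=[N+]=[N-])cc3)n2)c1` differs from compound 3 in one place: azido in place of acetamido on an aromatic carbon. Among the compounds with values here, no measured step exchanges these two groups directly, so the guidance comes from the steps around compound 3, where the acetamido group goes with the higher number and both the propyl and the amino group go with lower numbers. The azido group, like those two, has fewer heavy atoms than acetamido and no hydrogen-bond donor, so a return toward the lower numbers seems plausible, though not assured. Compound 4 is therefore expected to show a 2.6-fold lower number from compound 3 to compound 4 (0.41 log units; beyond the scatter), with an estimated value of 280 nM in this assay, in the range 120 nM to 650 nM.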

Compound 4, half-maximal inhibitory concentration: 558 nM
For compound 4 the middle estimate is 2.0-fold (0.30 log units) below the measured one; the measured number falls inside the stated range.
By their numbers in this assay, from the lowest: compounds 1 and 2 (each within the scatter of the next); then compounds 4 and 3 (each within the scatter of the next).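

In this assay, azido at this position, on an aromatic carbon para to a large group, stands with acetamido (a 1.3-fold lower number from compound 3 to compound 4 (0.11 log units; within the scatter)) and apart from amino (a 2.6-fold higher number from compound 2 to compound 4 (0.41 log units; beyond the scatter)) and propyl (a 2.7-fold higher number from compound 1 to compound 4 (0.43 log units; beyond the scatter)). Azido has fewer heavy atoms than acetamido and no hydrogen-bond donor, yet these differences alone did not bring the number to the level of compound 1 and compound 2, so neither count sorts the groups at this position on its own. Nothing measured here explains why azido falls with acetamido.

From the compounds shown here alone, it remains open whether a hydroxyl, a methoxy or a longer alkyl chain at this position would stand with compound 1 and compound 2 or with compound 3 and compound 4. Going by these compounds, a carboxylic acid here is equally open.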